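Amine replacements on the propoxy chain of the core

This account rests on a few compounds, and the source may have more. Where it says the series, first, only, none or still open, it means among the compounds named here.

Working notes on a small set sharing one core. Compound 1 `COc1cc2c(Nc3ccc(C#N)cc3)ncnc2cc1OCCCN(C)C` carries a dimethylamino group at the end of the propoxy chain. In a functional assay on HepG2 cells (Homo sapiens) for antiproliferative activity, read by MTT assay, with a stated time of 72 h (a lower number here means a stronger inhibitor, a higher number a weaker inhibitor), compound 1 gives > 100000 nM, which is a limit of the assay and not a number; compound 1 therefore stands only at the weak end of what was measured (the limit of > 100000 nM in this assay, at which 1 of the 3 values shown sits). Compound 2 `CCN(CC)CCCOc1cc2ncnc(Nc3ccc(C#N)cc3)c2cc1OC` gives 59400 nM in this assay, and compound 3 `COc1cc2c(Nc3ccc(C#N)cc3)ncnc2cc1OCCCN1CCC(N2CCCCC2)CC1` gives 8840 nM.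

The measured steps: an at least 1.6-fold lower number from compound 1 to compound 2 (0.22 log units; that floor lies within the scatter); an at least 11-fold lower number from compound 1 to compound 3 (1.05 log units; beyond the scatter); a 6.7-fold lower number from compound 2 to compound 3 (0.83 log units; beyond the scatter). Enlarging the terminal amine from an open chain to a bicyclic saturated system is what moved the number.

Compound 4 `COc1cc2c(Nc3ccc(C#N)cc3)ncnc2cc1OCCCN1CCN(C)CC1` is not yet measured. Its difference from compound 1: 4-methylpiperazin-1-yl in place of dimethylamino on a saturated chain carbon, three bonds along the chain from an oxygen on an aromatic ring. The entering group is a six-membered ring with a second basic nitrogen, so the change sits between the step to compound 2 and the step to compound 3. The expected step is an at least 3.3-fold lower number from compound 1 to compound 4 (0.52 log units; beyond the scatter), a lower number beyond the scatter, though smaller than that to compound 3. The estimate for compound 4 in this assay is 30000 nM, with a range from 8000 nM to 100000 nM.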

Compound 4, half-maximal inhibitory concentration: 13800 nM
For compound 4 the middle estimate is 2.2-fold (0.34 log units) above the measured one, and the stated range covers the measured number.
By their numbers in this assay, from the lowest: compounds 3 and 4 (each within the scatter of the next); then compound 2. At a limit, above all of these: compound 1.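

In this assay, 4-methylpiperazin-1-yl at this place gives an at least 7.2-fold lower number from compound 1 to compound 4 (0.86 log units; beyond the scatter) and a 4.3-fold lower number from compound 2 to compound 4 (0.63 log units; beyond the scatter) so a single six-membered non-aromatic ring on the propoxy chain already moves the number beyond the scatter from both open-chain amines. The second ring of the 4-(piperidin-1-yl)piperidin-1-yl group is therefore not required for a shift of this kind, and the two ring amines cannot be told apart on a 1.6-fold higher number from compound 3 to compound 4 (0.19 log units; within the scatter) which leaves the enlargement of the terminal amine, rather than the bicyclic system as such, as the better reading of these compounds. The step from compound 1 gives only a floor since compound 1 is a limit of the assay and not a number: the limit of > 100000 nM in this assay, at which 1 of the 4 values shown sits.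

Going by these compounds, whether the second ring nitrogen of compound 4 contributes stays open, and a piperidin-1-yl or morpholin-4-yl group on the same chain would address that. The compounds shown also leave open how the number responds to a shorter ethoxy or longer butoxy chain carrying 4-methylpiperazin-1-yl, or to another group in place of the nitrile.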